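Smaller Alkenyl Group on the Double-Bonded Nitrogen

This account rests on a few compounds, and the source may have more. Where it says the series, first, only, none or still open, it means among the compounds named here.

Compound 1, `C/N=C(\NC#N)Nc1cccnc1`: > 50 mg/kg, a limit of the assay rather than a number.
Compound 2, `CCC(CC)/N=C(\NC#N)Nc1cccnc1`: 20 mg/kg.
Compound 3, `CCCC(C)(C)/N=C(\NC#N)Nc1cccnc1`: 1 mg/kg.

All three were tested in a functional assay on the whole organism (blood, strain Wistar-Okamoto) with Rattus norvegicus as the target, with a stated time of 5 days; on this read-out lower numbers stand for an effect already at smaller amounts and higher numbers for an effect only at larger amounts of compound. For compound 1 the result is only a limit, (the limit of > 50 mg/kg in this assay, at which 1 of the 3 values shown sits). Among the numbers shown, compound 3 stands lowest: the step of a 20-fold lower number from compound 2 to compound 3 (1.30 log units; beyond the scatter) lies beyond the scatter, and the step of an at least 50-fold lower number from compound 1 to compound 3 (1.69 log units; beyond the scatter) does as well, so compound 3 is the most potent of the measured set.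

Compound 4, `C=C(C)C/N=C(\NC#N)Nc1cccnc1`, has not been measured. It differs from compound 3 in one place: 2-methylprop-2-en-1-yl in place of 1,1-dimethylbutyl on a double-bonded nitrogen.

The two measured steps that bear on this change are an at least 50-fold lower number from compound 1 to compound 3 (1.69 log units; beyond the scatter) and a 20-fold lower number from compound 2 to compound 3 (1.30 log units; beyond the scatter). Both were large, and both ran toward lower numbers when 1,1-dimethylbutyl took the place of a smaller group on the double-bonded nitrogen. Replacing 1,1-dimethylbutyl with 2-methylprop-2-en-1-yl is therefore expected to undo a good part of that gain, giving a step of a 30-fold higher number from compound 3 to compound 4 (1.48 log units; beyond the scatter) toward higher numbers. Compound 4 is estimated at 30 mg/kg, with an expected range from 8 mg/kg to 100 mg/kg.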

Compound 4, minimum effective dose: 20 mg/kg
Compound 4: middle estimate off by 1.5-fold (0.18 log units), on the high side; measured number inside the range.
By their numbers in this assay, from the lowest: compound 3; then compounds 2 and 4 (each within the scatter of the next). At a limit, above all of these: compound 1.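

In this assay, two different groups on the double-bonded nitrogen, pentan-3-yl and the unsaturated 2-methylprop-2-en-1-yl, cannot be told apart, with no change at the digits printed from compound 2 to compound 4 (within the scatter); at this position, then, a double bond outside aromatic rings does not set a group apart from a saturated one among the compounds shown. The sharp contrast comes with 1,1-dimethylbutyl, where the reading shows a 20-fold higher number from compound 3 to compound 4 (1.30 log units; beyond the scatter), so replacing methyl with a larger carbon group does not by itself bring the low number seen for compound 3, and 1,1-dimethylbutyl now stands apart from both other larger groups. The comparison with methyl can be read only loosely, as an at least 2.5-fold lower number from compound 1 to compound 4 (0.39 log units; beyond the scatter), and it rests on a limit for compound 1: the limit of > 50 mg/kg in this assay, at which 1 of the 4 values shown sits.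

The compounds shown leave open which feature of 1,1-dimethylbutyl goes with its low number. A tert-butyl group or a straight hexyl chain on the double-bonded nitrogen would help to separate branching from chain length, and a saturated 2-methylpropyl group would test the double bond of compound 4 directly.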